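The compounds below may be only part of what the source reports. "The series", "measured", "known", "first", "only" and "open" are said of these compounds alone.

Measured so far:

Compound 1, `COc1c(OCCCCN2CCN(C)CC2)cc(O)c2c(=O)cc(-c3ccc(Cl)cc3)oc12`: 2090 nM
Compound 2, `CN(C)CCCOc1c(OCc2ccccc2)cc(O)c2c(=O)cc(-c3ccccc3)oc12`: 5420 nM

Both compounds were tested in a functional assay on B16 cells (Mus musculus) for cytotoxicity, read by MTT assay, with a stated time of 72 h; a lower number here means a stronger inhibitor, a higher number a weaker inhibitor. Among the two numbers, compound 2 stands at the higher end with 5420 nM, and compound 1 sits lower with 2090 nM, a gap that lies beyond the usual scatter of the assay. The two compounds differ in more than one place, so nothing is said here about which of their differences is behind the gap.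

Compound 3, `CCN(CC)CCCOc1c(OCc2ccccc2)cc(O)c2c(=O)cc(-c3ccccc3)oc12`, has not yet been measured in this assay. It is compound 2 with one change: diethylamino in place of dimethylamino on a saturated chain carbon, three bonds along the chain from an oxygen on an aromatic ring. For the measured compounds named here, this is a small alteration at the outer end of the chain, and no measured pair in the present data shows what such a swap does. Without such a pair, the expectation for compound 3 is a change of modest size, and most likely none beyond the scatter; the step from compound 2 to compound 3 is estimated as a 1.1-fold lower number from compound 2 to compound 3 (0.04 log units; within the scatter). On that basis compound 3 is expected to give about 5000 nM in this assay, with a range from 2200 nM to 11000 nM.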

Compound 3, half-maximal inhibitory concentration: 4900 nM
Beside the measured number, compound 3's estimate is 1.0-fold (0.01 log units) above it; low and high end bracket the measured number.
By their numbers in this assay, from the lowest: compound 1; then compounds 3 and 2 (each within the scatter of the next).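

In this assay, the swap of dimethylamino for diethylamino on a saturated chain carbon, three bonds along the chain from an oxygen on an aromatic ring, gives a 1.1-fold lower number from compound 2 to compound 3 (0.04 log units; within the scatter). For the compounds shown here, this is the first pair in the set that differs in one place only, and it shows that going from the 3 heavy atoms of dimethylamino to the 5 heavy atoms of diethylamino at the outer end of the chain leaves the two compounds indistinguishable in this test. No independent measurement accompanies these numbers that could say why the reading holds steady at this position.

On these data alone, a single swap between two small open-chain amines says little about the position as a whole, so it remains open what a ring amine such as morpholine or pyrrolidine, or a primary amine, would do at the end of the same chain. Also open, as far as these compounds go, is whether the reading would stay as steady with a longer chain than the 3-(dimethylamino)propyl group carrying the amine, or with a carboxylic acid in place of the amine.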